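Removing one chloro from compound 3

This account rests on a few compounds, and the source may have more. Where it says the series, first, only, none or still open, it means among the compounds named here.

Compound 3 `O=C(c1cccnc1)c1cc(Cl)cc(Cl)c1O` gives 28700 nM in a functional assay on PC-3 cells (Homo sapiens) for cytotoxicity, read by sulforhodamine B assay, with a stated time of 48 h; a higher number here means a weaker inhibitor, a lower number a stronger inhibitor; compound 1 `O=C(c1cccnc1)c1ccccc1O` gives 33400 nM, and the two lie within the usual scatter of one another, so neither stands apart. For compound 2 `C=CCOc1c(Cl)cccc1C(=O)c1cccnc1` this assay records only a limit, > 100000 nM (the limit of > 100000 nM in this assay, at which 1 of the 3 values shown sits). The next step, to compound 4 `O=C(c1cccnc1)c1cccc(Cl)c1O`, is hydrogen in place of chloro on an aromatic carbon. Going by the values given here, no measured pair mirrors this step. Because compound 1 at 33400 nM and compound 3 at 28700 nM sit within scatter despite differing in chloro substitution, the loss of one chloro is expected to move the number no further than the scatter. Compound 4 is therefore estimated at 31000 nM, between 15000 nM and 65000 nM, an expected step of a 1.1-fold higher number from compound 3 to compound 4 (0.03 log units; within the scatter).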

Compound 4, half-maximal inhibitory concentration: 31500 nM
For compound 4 the middle estimate is 1.0-fold (0.01 log units) below the measured one; the measured number falls inside the stated range.
By their numbers in this assay, from the lowest: compounds 3, 4 and 1 (each within the scatter of the next). At a limit, above all of these: compound 2.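

In this assay the chloro para to a hydroxy group gives way to hydrogen with no readable change (a 1.1-fold higher number from compound 3 to compound 4 (0.04 log units; within the scatter)), and the remaining chloro, set in place of hydrogen, does likewise (a 1.1-fold lower number from compound 1 to compound 4 (0.03 log units; within the scatter)), so neither chloro alone moves the number beyond the scatter. Hydrogen in place of allyl on the oxygen gives the only step here beyond the scatter (an at least 3.1-fold lower number from compound 2 to compound 4 (0.50 log units; beyond the scatter)). Compound 2 is held at a limit, not a number: the limit of > 100000 nM in this assay, at which 1 of the 4 values shown sits.

The compounds shown carry only chloro or hydrogen para to the hydroxy group, so the effect of an amine or a carboxylic acid there remains open.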